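The source may hold more compounds than are shown below. What is called first, only, known or untested is meant among the compounds shown, and "the series" means these compounds.

Compound 2 `COc1cc(C(c2ccc(O)c(OC)c2)[C@@H](C)C(C)C)ccc1O` is the reference point here. In a functional assay on HL-60 cells (Homo sapiens) for cytotoxicity, read by WST assay, with a stated time of 48 h (a lower number here means a stronger inhibitor, a higher number a weaker inhibitor), compound 2 gives 20000 nM, the lowest number among the three measured compounds. Compound 1 `COC[C@H](C)[C@H](C)C(c1ccc(O)c(OC)c1)c1ccc(O)c(OC)c1` gives 82000 nM in this assay, and compound 3 `COc1cc(C(c2ccc(O)c(OC)c2)[C@H](C)[C@H](C)CF)ccc1O` gives 56000 nM. The steps between them are of modest size: a 4.1-fold lower number from compound 1 to compound 2 (0.61 log units; beyond the scatter), a 2.8-fold higher number from compound 2 to compound 3 (0.45 log units; beyond the scatter), while a 1.5-fold lower number from compound 1 to compound 3 (0.17 log units; within the scatter).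

Compound 4 `COc1cc(C(c2ccc(O)c(OC)c2)[C@@H](CF)C(C)C)ccc1O` differs from compound 2 in one place: fluoro in place of hydrogen on a saturated chain carbon, three bonds along the chain from two aromatic carbons. Among the compounds with values here, the closest precedent is the step from compound 2 to compound 3, where a fluoromethyl group also enters, though one bond further out, and that step gave a 2.8-fold higher number from compound 2 to compound 3 (0.45 log units; beyond the scatter). The step from compound 1 to compound 2, where a methoxy group leaves, gave a 4.1-fold lower number from compound 1 to compound 2 (0.61 log units; beyond the scatter), so removing or adding a small substituent on this chain has moved the numbers only modestly. A modest rise in the number for compound 4 is therefore expected, of about a 2.0-fold higher number from compound 2 to compound 4 (0.30 log units; within the scatter). The estimate for compound 4 in this assay is 40000 nM, with a range from 15000 nM to 100000 nM.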

Compound 4, half-maximal inhibitory concentration: 39000 nM
Beside the measured number, compound 4's estimate is 1.0-fold (0.01 log units) above it, and the stated range covers the measured number.
By their numbers in this assay, from the lowest: compounds 2, 4, 3 and 1 (each within the scatter of the next, the first and the last beyond it).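

In this assay, fluoro in place of hydrogen on this saturated chain carbon gives a 2.0-fold higher number from compound 2 to compound 4 (0.29 log units; within the scatter), so at this position the change cannot be told apart from the ordinary spread of repeated measurements. Exchanging 2-(fluoromethyl)-1-methylpropyl for 1-(fluoromethyl)-2-methylpropyl gives a 1.4-fold lower number from compound 3 to compound 4 (0.16 log units; within the scatter), which is also too small to read, whereas 1-(fluoromethyl)-2-methylpropyl in place of 2-(methoxymethyl)-1-methylpropyl gives a 2.1-fold lower number from compound 1 to compound 4 (0.32 log units; beyond the scatter), a modest step. No measurement is available that would explain these numbers.

The compounds shown leave open what an amine, a hydroxyl or a carboxylic acid at this chain carbon would do to the number, and whether a longer chain would behave like fluoromethyl. They also leave open whether these small steps would hold in other cell types.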